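A few compounds are considered here, and "the series" means these few. Any claim that something is new, unique, unknown or untested is made for them only; others in the source may bear on it.

In a functional assay on NCI-N87 cells (Homo sapiens) for antiproliferative activity (on this read-out lower numbers stand for stronger inhibition and higher numbers for weaker inhibition), compound 1 (`Cc1ccccc1Nc1ncnn2ccc(CN3CCC(N)CC3)c12`) gives 3300 nM while compound 2 (`NC1CCN(Cc2ccn3ncnc(Nc4cccc(Cl)c4)c23)CC1`) gives 60 nM and compound 3 (`NC1CCN(Cc2ccn3ncnc(Nc4cccc(Br)c4)c23)CC1`) gives 50 nM in the same test. Compound 3 therefore stands level with compound 2 and far under compound 1. Exchanging chloro for bromo gives a 1.2-fold lower number from compound 2 to compound 3 (0.08 log units; within the scatter) and stays inside the scatter, whereas replacing 2-methylphenyl gives a 55-fold lower number from compound 1 to compound 2 (1.74 log units; beyond the scatter) and a 66-fold lower number from compound 1 to compound 3 (1.82 log units; beyond the scatter) as large steps. Compound 4 (`COc1ccc(Nc2ncnn3ccc(CN4CCC(N)CC4)c23)cc1Cl`) carries a new group at the same place (3-chloro-4-methoxyphenyl in place of 3-bromophenyl on a nitrogen on an aromatic ring). Going by the values given here, it has a chloro, as compound 2 does, but no measured compound has a methoxy, so uncertainty remains. The expected result in this assay is a 1.6-fold higher number from compound 3 to compound 4 (0.20 log units; within the scatter) and thus no move beyond the scatter. Compound 4 is estimated at 80 nM with an expected range from 20 nM to 350 nM in this test.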

Compound 4, half-maximal inhibitory concentration: 1210 nM
The estimate for compound 4 lay 15-fold (1.18 log units) below the measured number; the whole stated range lies below it.
By their numbers in this assay, from the lowest: compounds 3 and 2 (each within the scatter of the next); then compound 4; then compound 1.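

In this assay, the only difference between the two compounds is one methoxy on an aromatic carbon, and it brings a large change (a 20-fold higher number from compound 2 to compound 4 (1.30 log units; beyond the scatter)), so a chloro on the ring does not by itself secure a low number. The full exchange of groups is similarly large (a 24-fold higher number from compound 3 to compound 4 (1.38 log units; beyond the scatter)), yet 3-chloro-4-methoxyphenyl still surpasses 2-methylphenyl (a 2.7-fold lower number from compound 1 to compound 4 (0.44 log units; beyond the scatter)). No supporting data explain this loss. From the compounds shown here alone, it remains open whether a fluoro, hydroxy or amine in place of that methoxy would behave alike. Also open, going by these compounds, is how a methoxy would fare without the chloro.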